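A few compounds are considered here, and "the series" means these few. Any claim that something is new, unique, unknown or untested is made for them only; others in the source may bear on it.

Measured so far:
compound 1 `COc1cccc(CNC(=O)c2nc(Br)c3cccnc3c2N[C@H]2CC[C@H](N)CC2)c1`: 7000 nM
compound 2 `C[C@@H](CO)Nc1nc(C(=O)NCc2ccc(F)cc2)c(O)c2ncccc12`: a limit, > 20000 nM
compound 3 `C[C@H](CO)Nc1nc(C(=O)NCc2ccc(F)cc2)c(O)c2ncccc12`: a limit, > 20000 nM

Among the measured compounds shown here, in a functional assay on MDA-MB-435 cells (Homo sapiens) for cytotoxicity, read by MTT assay, with a stated time of 72 h (on this read-out higher numbers stand for weaker inhibition and lower numbers for stronger inhibition), compound 1 gives 7000 nM, the only actual number among the three results. Compound 2 reaches only the limit > 20000 nM. Compound 3 likewise stops at the limit > 20000 nM. The step that the two limits leave unreadable from compound 2 to compound 3 stays unreadable because of the limit of > 20000 nM in this assay, at which 2 of the 3 values shown sit, even though the fact that compounds 2 and 3 differ only in the configuration as drawn shows that the pair differ in nothing else.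

Compound 4 `C[C@H](NC(=O)c1nc(Br)c2cccnc2c1N[C@H]1CC[C@H](N)CC1)c1ccc(F)cc1` keeps the core of compound 1 and alters only the group on the amide nitrogen: 1-(4-fluorophenyl)ethyl in place of 3-methoxybenzyl on an amide-type nitrogen. No measured step touches this position, and compounds 2 and 3 carry a different core and yield only limits, so nothing shown speaks for or against a change in potency here. The step of a 1.2-fold lower number from compound 1 to compound 4 (0.07 log units; within the scatter) is therefore expected to stay within the usual scatter. Compound 4 is estimated to give about 6000 nM in this assay, with a range from 1500 nM to 20000 nM.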

Compound 4, half-maximal inhibitory concentration: > 10000 nM
Compound 4: a limit, no number; the forecaster's own chance of this, stated with the estimate: 15%; middle value at least 1.6-fold (0.22 log units) away from the limit.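

Compound 4 ends at a limit in this assay, > 10000 nM, and not at a number. Placing 1-(4-fluorophenyl)ethyl in place of 3-methoxybenzyl on the amide-type nitrogen gives an at least 1.4-fold higher number from compound 1 to compound 4 (0.15 log units; that floor lies within the scatter), so this first measured change at the position shows no gain in potency, but it does not establish a loss beyond the scatter either. The true size of the step stays unknown because of this: the limit of > 10000 nM in this assay, at which 1 of the 4 values shown sits.

The change replaces the methoxy-bearing ring with a fluorine-bearing one and adds a defined stereocentre at the same time, and the compounds shown do not separate these two differences. Also open, from the compounds shown here alone, is how the shared core responds when this position carries a different kind of group, such as an unsubstituted benzyl, a carboxylic acid or an aminoethyl chain.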